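A Second Chloro on the Amide Ring of Compound 1

The compounds below may be only part of what the source reports. "The series", "measured", "known", "first", "only" and "open" are said of these compounds alone.

Compound 1 `O=C(Nc1cccc(/C=C/C(=O)c2nc3ccccc3[nH]2)c1)c1cccc(Cl)c1` carries a 3-chlorophenyl group on its amide, and in a functional assay on HCT-116 cells (Homo sapiens) for antiproliferative activity, read by MTT assay, with a stated time of 48 h (on this read-out higher numbers stand for weaker inhibition and lower numbers for stronger inhibition), compound 1 gives 1120 nM. Within the data shown here, that is the lowest of the three numbers measured so far. Compound 2 `O=C(Nc1cccc(/C=C/C(=O)c2nc3ccccc3[nH]2)c1)c1cccc(C(F)(F)F)c1` gives 3360 nM, a step of a 3.0-fold higher number from compound 1 to compound 2 (0.48 log units; beyond the scatter). Compound 3 `COc1cccc(C(=O)Nc2cccc(/C=C/C(=O)c3nc4ccccc4[nH]3)c2)c1` gives 3680 nM, a step of a 3.3-fold higher number from compound 1 to compound 3 (0.52 log units; beyond the scatter). Between those two, a 1.1-fold higher number from compound 2 to compound 3 (0.04 log units; within the scatter), so they cannot be told apart.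

Compound 4 `O=C(Nc1cccc(/C=C/C(=O)c2nc3ccccc3[nH]2)c1)c1cc(Cl)cc(Cl)c1` adds one more group to compound 1: chloro in place of hydrogen on an aromatic carbon. The new chloro sits on an aromatic carbon of the six-membered aromatic ring of carbon only, meta to a chloro group and meta to a large group, so the 3-chlorophenyl becomes a 3,5-dichlorophenyl.

Among the measured compounds shown here, none of the measured steps adds a group; each swaps the chloro for something else, and both swaps away from chloro weakened the compound by a modest amount. For the measured compounds named here, no step shows what a second chloro does. The chloro is the best of the three groups tried at that ring, which gives some reason to expect that keeping it and adding another leaves the number near compound 1, with a step of a 1.2-fold lower number from compound 1 to compound 4 (0.09 log units; within the scatter) that need not exceed the scatter. Compound 4 is therefore estimated at 900 nM, in the range from 350 nM to 2500 nM.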

Compound 4, half-maximal inhibitory concentration: 1650 nM
Compound 4: middle estimate off by 1.8-fold (0.26 log units), on the low side; low and high end bracket the measured number.
By their numbers in this assay, from the lowest: compounds 1 and 4 (each within the scatter of the next); then compounds 2 and 3 (each within the scatter of the next).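

In this assay, among these compounds, the step of a 1.5-fold higher number from compound 1 to compound 4 (0.17 log units; within the scatter) is the first one here that adds a group instead of swapping one, and it shows that a second chloro on this aromatic carbon, meta to a chloro group, cannot be told apart from the hydrogen it replaces. The 3,5-dichlorophenyl group therefore stays ahead of the other two rings tried, with a 2.2-fold lower number from compound 3 to compound 4 (0.35 log units; beyond the scatter) and with a 2.0-fold lower number from compound 2 to compound 4 (0.31 log units; beyond the scatter), both modest steps, so compound 1 and compound 4 together form the better pair in this small set. Nothing measured here explains why the extra chloro leaves the number within the scatter, or why these rings rank as they do.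

The compounds shown test only chloro at this new position, so it remains open whether a fluoro, a bromo, an amine or a carboxylic acid on the same carbon would also leave the number in place or would move it beyond the scatter. As far as these compounds go, it also remains open whether the 3,5-dichlorophenyl group would behave the same way on a changed core.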